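Swapping the ethylcyclohexyl arm for a single fluorine

A few compounds are considered here, and "the series" means these few. Any claim that something is new, unique, unknown or untested is made for them only; others in the source may bear on it.

Measured compounds in an ADME assay on MT4 cells (Homo sapiens) for cytotoxicity; a lower number here means that less compound is tolerated, a higher number that more compound is tolerated:
compound 1 `CC[C@H]1CC[C@H](c2ccc(NC(=S)Nc3cccc(C(F)(F)F)c3)cc2)CC1` gives 39000 nM
compound 2 `FC(F)(F)c1cccc(NC(=S)Nc2ccc(Cl)cc2)c1` gives 6800 nM
compound 3 `N#Cc1ccc(NC(=S)Nc2cccc(C(F)(F)F)c2)cc1` gives 7000 nM

Compound 1 holds the highest number of the three, beyond the scatter from both compound 2 and compound 3, so it is the one of which the cells tolerate the most. Two measured steps already replace the 4-ethylcyclohexyl group with a small substituent on the same aromatic carbon: a 5.7-fold lower number from compound 1 to compound 2 (0.76 log units; beyond the scatter) and a 5.6-fold lower number from compound 1 to compound 3 (0.75 log units; beyond the scatter); both lower the number by about the same amount, while a 1.0-fold higher number from compound 2 to compound 3 (0.01 log units; within the scatter) shows that swapping one small substituent for another makes no difference beyond the scatter.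

Compound 4 `Fc1ccc(NC(=S)Nc2cccc(C(F)(F)F)c2)cc1` is compound 1 with the change (fluoro in place of 4-ethylcyclohexyl on an aromatic carbon). Because the two measured steps from compound 1, a 5.7-fold lower number from compound 1 to compound 2 (0.76 log units; beyond the scatter) and a 5.6-fold lower number from compound 1 to compound 3 (0.75 log units; beyond the scatter), agree closely, a lowering of similar size is expected, giving an expected step of a 4.9-fold lower number from compound 1 to compound 4 (0.69 log units; beyond the scatter) in this assay. The estimate for compound 4 is 8000 nM with a range from 3500 nM to 18000 nM.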

Compound 4, half-maximal cytotoxic concentration: 31000 nM
The estimate for compound 4 lay 3.9-fold (0.59 log units) below the measured number, and the stated range ends below it.
By their numbers in this assay, from the lowest: compounds 2 and 3 (each within the scatter of the next); then compounds 4 and 1 (each within the scatter of the next).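

In this assay, compounds 2 and 3 had suggested that any small substituent on this aromatic carbon would give a clearly lower number than the 4-ethylcyclohexyl group of compound 1, but compound 4 goes against that reading (a 1.3-fold lower number from compound 1 to compound 4 (0.10 log units; within the scatter)). The small substituents therefore do not form one class at this position: fluoro stands apart from both cyano (a 4.4-fold higher number from compound 3 to compound 4 (0.65 log units; beyond the scatter)) and chloro (a 4.6-fold higher number from compound 2 to compound 4 (0.66 log units; beyond the scatter)), so the size of the group leaving or entering does not by itself set the number across these compounds. No measurement at hand accounts for the separation of fluoro from chloro and cyano.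

The compounds shown leave open whether an amine, a carboxylic acid or a methoxy group on this carbon would fall with compounds 2 and 3 or with compounds 1 and 4. They also leave open where a short alkyl chain would fall.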